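Carboxy in Place of Tert-Butyl on a Urea

This account rests on a few compounds, and the source may have more. Where it says the series, first, only, none or still open, it means among the compounds named here.

Compound 1, `Cc1cc(NC(=O)Nc2ccc(C(C)(C)C)cc2)c2ccccc2n1`, was tested in an ADME assay on HEK293 cells (Homo sapiens) for cytotoxicity, with a stated time of 72 h; a higher number here means that more compound is needed for the effect, a lower number that less compound is needed. For compound 1 the result is a limit of the assay, > 25000 nM, and not a number. Compound 2, `Cc1cc(NC(=O)Nc2cccc([N+](=O)[O-])c2)c2ccccc2n1`, is also measured in this assay, and its result is again a limit, > 25000 nM. Both measured values sit at the limit of > 25000 nM in this assay, at which 2 of the 2 values shown sit. Compound 3, `Cc1cc(NC(=O)Nc2ccc(C(=O)O)cc2)c2ccccc2n1`, is not yet measured and differs from compound 1 by carboxy in place of tert-butyl on an aromatic carbon. Because both measured compounds stop at the limit of > 25000 nM in this assay, at which 2 of the 2 values shown sit, the expected step that the limit leaves unreadable from compound 1 to compound 3 is none beyond the scatter. For compound 3 the expected result is 30000 nM, within 12000 nM to 80000 nM.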

Compound 3, half-maximal effective concentration: > 25000 nM
Compound 3 gave a limit, no number; the forecaster's own chance of this, stated with the estimate: 85%; the middle value is on the limit's open side.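

Among the compounds shown here, no step from compound 1 to compound 3 can be read, because both results are limits and not numbers: the limit of > 25000 nM in this assay, at which 3 of the 3 values shown sit. The compounds shown leave open what concentration, if any, would produce the effect for each of them.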